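Fluoro for chloro on the phenoxy ring of compound 2

This account rests on a few compounds, and the source may have more. Where it says the series, first, only, none or still open, it means among the compounds named here.

Measured compounds:
compound 1 `COc1ccc(N2CCN(CC(O)COc3ccc(Cl)cc3)CC2)cc1`: 4.6%
compound 2 `O=[N+]([O-])c1ccc(N2CCN(CC(O)COc3ccc(Cl)cc3)CC2)cc1`: 24.8%

Both compounds were measured in a functional assay on the whole organism (blood) with Rattus norvegicus as the target, at a dose of 100 mg/kg by the oral route; on this read-out higher numbers stand for more inhibition at the one dose given (going by the name of the read-out) and lower numbers for less inhibition. Compound 1 gave 4.6%, and compound 2 gave 24.8%. Going by the values given here, the one measured step between them, nitro in place of methoxy on an aromatic carbon, amounted to a number 20.2 percentage points higher from compound 1 to compound 2 (beyond the scatter). Of the two numbers, compound 2 stands highest, and its nearest neighbour is compound 1 with the lower number.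

Compound 3 `O=[N+]([O-])c1ccc(N2CCN(CC(O)COc3ccc(F)cc3)CC2)cc1` is not yet measured. It differs from compound 2 in one place: fluoro in place of chloro on an aromatic carbon. Among the compounds with values here, no measured step touches this place or this change; the only step seen concerns the nitro group on the other ring, and compound 2 already carries that group. There is therefore nothing in the two measured values that speaks for a shift in either direction, and the expectation for this assay is a step of no size beyond the scatter.

The estimated step from compound 2 to compound 3 is a number 3.8 percentage points lower from compound 2 to compound 3 (within the scatter). Compound 3 is thus expected to give about 21%, with a range from 5% to 38%.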

Compound 3, a percentage reported as inhibition, in the whole organism at one dose (the size of the read-out at that dose, not a potency): 40.2%
The estimate for compound 3 lay 19.2 percentage points below the measured number, and the stated range ends below it.
By their numbers in this assay, from the lowest: compound 1; then compound 2; then compound 3.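

In this assay, the change from 4-chlorophenoxy to 4-fluorophenoxy gave a number 15.4 percentage points higher from compound 2 to compound 3 (beyond the scatter), so the halogen para to a large group on the phenoxy ring is a place where the read-out moves, even with the nitro group held fixed. Until now, the only movement seen had come from the other aromatic ring, whereas this step shows that a single-atom exchange at the far end of the molecule can also shift the number beyond the scatter, with one heavy atom leaving, one entering, and no change in the counted hydrogen-bond donors, acceptors or net charge. No measurement at hand bears on what lies behind this rise.

The compounds shown leave open whether the same exchange would carry over to the methoxy series of compound 1, and how other groups in this place, such as a methyl, a nitrile or a trifluoromethyl, would read. They also cover a single dose only, so these numbers give the size of the effect at that dose and leave any ranking by potency unsettled.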